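Replacing one chloroaryl group with another at the ring nitrogen

The source may report more compounds than this note shows. Statements on the series, on what has been measured and on what is new or still open speak of the compounds shown alone.

Compound 2 `N#CC1=C(N)Oc2c(N)cc3nc4ccccc4nc3c2C12C(=O)N(Cc1cnnn1-c1ccc(Cl)cc1Cl)c1ccccc12` sits at the weak end of what is shown in a functional assay on HepG2 cells (Homo sapiens) for antiproliferative activity, read by MTT assay, with a stated time of 48 h; a lower number here means a stronger inhibitor, a higher number a weaker inhibitor: in this assay compound 2 gives only a limit, > 50000 nM. The related compound 1 `N#CC1=C(N)Oc2c(N)cc3nc4ccccc4nc3c2C12C(=O)N(Cc1cnnn1-c1ccccc1Cl)c1ccccc12`, differing by a chloro in place of hydrogen on an aromatic carbon, gives 33500 nM in this assay. Within the data shown here, the one measured step, an at least 1.4-fold higher number from compound 1 to compound 2 (0.17 log units; that floor lies within the scatter), is bounded by the limit of > 50000 nM in this assay, at which 1 of the 2 values shown sits.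

Compound 3 `Cc1ccc(-n2nncc2CN2C(=O)C3(C(C#N)=C(N)Oc4c(N)cc5nc6ccccc6nc5c43)c3ccccc32)cc1Cl` has not been measured. It differs from compound 2 by 3-chloro-4-methylphenyl in place of 2,4-dichlorophenyl on an aromatic nitrogen. Among the measured compounds shown here, the only measured step, an at least 1.4-fold higher number from compound 1 to compound 2 (0.17 log units; that floor lies within the scatter), concerns a change within this same group and shows nothing beyond the scatter, so no step beyond the scatter is expected for an at least 1.1-fold lower number from compound 2 to compound 3 (0.04 log units; that floor lies within the scatter). Compound 3 is therefore expected to give about 45000 nM, between 20000 nM and 100000 nM, with a fair chance that this assay again reports only a limit.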

Compound 3, half-maximal inhibitory concentration: > 50000 nM
Compound 3 ended at the assay's limit; the forecaster's own chance of this, stated with the estimate: 55%; middle value at least 1.1-fold (0.04 log units) from the limit.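

In this assay, the step between compound 2 and compound 3 cannot be read, because both end at a limit: the limit of > 50000 nM in this assay, at which 2 of the 3 values shown sit. Among these compounds, the one readable step is an at least 1.4-fold higher number from compound 1 to compound 3 (0.17 log units; that floor lies within the scatter), for 3-chloro-4-methylphenyl in place of 2-chlorophenyl on the same aromatic nitrogen. Among the compounds shown here, two differently substituted phenyl groups at this position, one with two chlorines and one with a chlorine and a methyl, now give only a limit, and compound 1 is the only compound here with a measured number.

The compounds shown leave open how far beyond the limit compound 2 and compound 3 lie. They also leave open whether a phenyl ring bearing an amine or a carboxylic acid, or a longer chain in place of the phenyl, would give a measurable number at this position.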